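This account rests on a few compounds, and the source may have more. Where it says the series, first, only, none or still open, it means among the compounds named here.

Measured so far in an in vitro ADME assay on microsomes from liver (Macaca mulatta) for metabolic stability, using NADPH, with a stated time of 10 min, tested at 0.5 uM; on this read-out lower numbers stand for a shorter-lived compound and higher numbers for a longer-lived compound:
- compound 1 `COc1cc(C2CCNCC2)ccc1Nc1ncc2ccc(-c3ccccc3N(C)S(C)(=O)=O)n2n1` gives < 0.0834 h (a limit)
- compound 2 `CNC(=O)CN1CCC(c2ccc(Nc3ncc4ccc(-c5ccccc5OC)n4n3)c(OC)c2)CC1` gives < 0.2 h (a limit)

For compound 1 the limit < 0.0834 h is all that is known so far, with no actual number behind it. Compound 3 `COc1cc(C2CCN(CC(N)=O)CC2)ccc1Nc1ncc2ccc(-c3ccccc3N(C)S(C)(=O)=O)n2n1` differs from compound 1 by carbamoylmethyl in place of hydrogen on an amine nitrogen in a ring. Going by the values given here, no measured step sizes this change. The expected step of an at least 1.0-fold higher number from compound 1 to compound 3 (0.03 log units; that floor lies within the scatter) in this assay is none beyond the scatter, with no direction favoured. For compound 3 the estimated half-life is 0.09 h (0.04 h to 0.25 h), and a report as a limit again is expected.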

Compound 3, half-life: < 0.0834 h
Compound 3 ended at the assay's limit; the forecaster's own chance of this, stated with the estimate: 65%; at least 1.0-fold (0.03 log units) between middle value and limit.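

Compound 1 and compound 3 both report only a limit in this assay, so no step can be read between them: the limit of < 0.0834 h in this assay, at which 2 of the 3 values shown sit.

The compounds shown leave open whether carbamoylmethyl in place of hydrogen on an amine nitrogen in a ring changes the half-life at all.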